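Inverting One Stereocentre of Compound 1

A few compounds are considered here, and "the series" means these few. Any claim that something is new, unique, unknown or untested is made for them only; others in the source may bear on it.

Compound 1 `CCCCC1([C@@H](O)/C=C/C2CCC(=O)[C@@H]2CCCCCCC(=O)O)CCC1`: 0.0139 mg/kg
Compound 2 `CCCCC1([C@H](O)/C=C/C2[C@H](O)CC(=O)[C@@H]2C/C=C\CCCC(=O)O)CCC1`: 0.00154 mg/kg
Compound 3 `CCCCC1([C@H](O)/C=C/C2CCC(=O)[C@@H]2C/C=C\CCCC(=O)OCC)CCC1`: 0.221 mg/kg

In a functional assay on the whole organism (strain Hartley) for inhibition, with Cavia porcellus as the target, with stated times of 15 min and 2 min (on this read-out higher numbers stand for an effect only at larger amounts of compound and lower numbers for an effect already at smaller amounts), compound 1 holds the middle place of the three, with compound 2 clearly lower and compound 3 clearly higher. Compound 4 `CCCCC1([C@H](O)/C=C/C2CCC(=O)[C@@H]2CCCCCCC(=O)O)CCC1` is its untested partner: the two compounds have the same atoms and bonds; at least one stereo element is drawn with a configuration in one of them and without one in the other: 1 of 4 stereo elements differ; a stereocentre at a saturated chain carbon is drawn S in compound 1 and R in compound 4. So a stereocentre at a saturated chain carbon is drawn S in compound 1 and R in compound 4. Within the data shown here, no measured pair isolates such a change. Compound 2 (0.00154 mg/kg) and compound 3 (0.221 mg/kg) share the arrangement of compound 4 at this stereocentre, but they differ from it elsewhere and their values lie on either side of compound 1. With little certainty, the modest step therefore expected is a 2.8-fold lower number from compound 1 to compound 4 (0.44 log units; beyond the scatter). The estimated value for compound 4 is 0.005 mg/kg, within 0.001 mg/kg to 0.03 mg/kg.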

Compound 4, dose for half-maximal effect: 0.0024 mg/kg
Compound 4: middle estimate off by 2.1-fold (0.32 log units), on the high side; the measured number falls inside the stated range.
By their numbers in this assay, from the lowest: compounds 2 and 4 (each within the scatter of the next); then compound 1; then compound 3.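

Among these compounds, compounds 2 and 3 differ from compound 1 in other places too, so only this pair isolates the stereocentre at a saturated chain carbon. In this assay, changing it from S to R alone gives a 5.8-fold lower number from compound 1 to compound 4 (0.76 log units; beyond the scatter), so the arrangement at this one carbon matters by itself. One caution applies to this pair: the fact that one of compounds 1 and 4 is drawn with a defined configuration and the other without, at the place where they differ

The compounds shown leave open whether the step keeps its size when the core carries other changes. They also leave open what an amine at this stereocentre would give.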